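The compounds below may be only part of what the source reports. "The series", "measured", "known", "first", "only" and "open" are said of these compounds alone.

Measured compounds in the series:

compound 1, `CCCCCCCCNC(=O)/C=C/c1c(/C=C/c2ccc(OC)cc2)cc(OC)cc1OC` — 8660 nM
compound 2, `CCC(C)NC(=O)/C=C/c1c(/C=C/c2ccc(OC)cc2)cc(OC)cc1OC` — 3950 nM

Both numbers come from a functional assay on A549 cells (Homo sapiens) for inhibition, read by MTT assay, with a stated time of 48 h; on this read-out lower numbers stand for stronger inhibition and higher numbers for weaker inhibition. Among the compounds with values here, compound 2 stands lowest of the two; its nearest neighbour is compound 1, and the only single-point step so far is a 2.2-fold lower number from compound 1 to compound 2 (0.34 log units; beyond the scatter), a modest movement in the direction of stronger inhibition when the shorter chain replaces the longer one on the amide nitrogen.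

Compound 3, `CCCCCN(CCCCC)C(=O)/C=C/c1c(/C=C/c2ccc(OC)cc2)cc(OC)cc1OC`, has not yet been measured. Its difference from compound 2 is dipentylamino in place of (sec-butyl)amino on a carbonyl carbon. The change removes the single hydrogen-bond donor and adds six heavy atoms of chain on the carbonyl carbon whose other neighbour is a double-bonded chain carbon.

Within the data shown here, only the step from compound 1 to compound 2 bears on this, and it runs the other way: more chain carbon on the nitrogen went with a higher number. By that guide, compound 3 is expected to return to a higher number, an estimated 2.2-fold higher number from compound 2 to compound 3 (0.33 log units; beyond the scatter), in the direction of weaker inhibition. Among the measured compounds shown here, with one step as the sole guide the range is wide. For compound 3 in this assay the estimate is 8500 nM, between 3000 nM and 25000 nM.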

Compound 3, half-maximal inhibitory concentration: 7490 nM
Compound 3: middle estimate off by 1.1-fold (0.05 log units), on the high side; the measured number falls inside the stated range.
By their numbers in this assay, from the lowest: compounds 2, 3 and 1 (each within the scatter of the next, the first and the last beyond it).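

In this assay, the change to dipentylamino on the carbonyl carbon gives a 1.9-fold higher number from compound 2 to compound 3 (0.28 log units; within the scatter) and, against the straight chain, a 1.2-fold lower number from compound 1 to compound 3 (0.06 log units; within the scatter); both steps stay within the scatter, so compound 3 cannot be told apart from either neighbour, even though compound 1 and compound 2 are separated beyond it. At this position, then, losing the amide hydrogen and adding chain atoms together produce no step beyond the scatter from compound 2, and the earlier link between more chain carbon and a higher number is neither confirmed nor contradicted by compound 3. No accompanying measurement offers an explanation for this reading.

Dipentylamino alters the amide hydrogen and the chain size in one move, so the contribution of each remains unresolved; a dimethylamino group on the same carbonyl carbon would give the two a separate reading. Also open, going by these compounds, is whether a chain ending in an amine or a carboxylic acid, or a ring such as morpholine or piperidine in this place, would move the number beyond the narrow span seen across these three compounds.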